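The source may hold more compounds than are shown below. What is called first, only, known or untested is meant among the compounds shown, and "the series" means these compounds.

Compound 1 `O=C(CCSc1nc2cc(F)ccc2o1)N1CCCC1` is the starting point: in an ADME assay on microsomes from liver (Mus musculus) for metabolic stability, read by LC-MS, using NADPH, with a stated time of 45 min, tested at 0.5 uM (on this read-out higher numbers stand for fast clearance and lower numbers for slow clearance), compound 1 gives 115 mL/min/g, the highest of the three numbers measured. Compound 3 `CC1CCCN1C(=O)CCSc1nc2cc(Cl)ccc2o1` gives 98 mL/min/g, which lies within the scatter of compound 1, while compound 2 `O=C(CCSc1nc2cc(Cl)ccc2o1)N1CCS(=O)(=O)C1` gives 8.9 mL/min/g, far lower. Going by the values given here, the only measured step, an 11-fold higher number from compound 2 to compound 3 (1.04 log units; beyond the scatter), concerns the group on the carbonyl carbon, not the part of the molecule changed here. Compound 4 `O=C(CCSc1nc2ccccc2o1)N1CCCC1` differs from compound 1 by hydrogen in place of fluoro on an aromatic carbon. Among the compounds with values here, no measured step touches this position, so there is no basis for expecting a step beyond the scatter in either direction. Compound 4 is therefore expected to give about 130 mL/min/g, between 65 mL/min/g and 260 mL/min/g. This would mean an expected 1.1-fold higher number from compound 1 to compound 4 (0.05 log units; within the scatter).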

Compound 4, intrinsic clearance in a liver preparation (reported as CLH), per the amount of preparation that the assay uses: 161 mL/min/g
For compound 4 the middle estimate is 1.2-fold (0.09 log units) below the measured one; the measured number falls inside the stated range.
By their numbers in this assay, from the lowest: compound 2; then compounds 3, 1 and 4 (each within the scatter of the next).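

In this assay, going by these compounds alone, hydrogen in place of fluoro on this aromatic carbon gives a 1.4-fold higher number from compound 1 to compound 4 (0.15 log units; within the scatter), the first measured step at this position. With the rest of the molecule unchanged, this swap does not separate the two compounds, so the fast clearance of compound 1 does not depend on the fluoro. No measurement shown here explains this result. On these data alone, it remains open whether a methoxy group or a nitrile on this carbon would give a step beyond the scatter. Also open, as far as these compounds go, is whether this swap would give a similar step with the 1,1-dioxo-1,3-thiazolidin-3-yl group of compound 2 on the carbonyl.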